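This account rests on a few compounds, and the source may have more. Where it says the series, first, only, none or still open, it means among the compounds named here.

Measured in an assay on FRT-Jurkat cells for inhibition of nuclear factor NF-kappa-B complex (Homo sapiens), read by flow cytometry, with a stated time of 24 h, tested at 10 uM; on this read-out higher numbers stand for more inhibition at the one concentration tested (going by the name of the read-out) and lower numbers for less inhibition:
compound 1 `Cc1ccccc1Nc1ccc2c(c1)C(=O)N(C1CCC(=O)NC1=O)C2=O` gives 2%;
compound 2 `COc1ccc(Nc2cccc3c2C(=O)N(C2CCC(=O)NC2=O)C3=O)cc1` gives 13%;
compound 3 `CCCc1ccc(Nc2cccc3c2C(=O)N(C2CCC(=O)NC2=O)C3=O)cc1` gives 23%.

Among these three, compound 1 stands lowest in this assay. Compound 2 lies nearest to it, yet that gap is beyond the usual scatter; compound 3 lies furthest, also beyond the scatter. Compound 4 `O=C1CCC(N2C(=O)c3ccc(Nc4ccccn4)cc3C2=O)C(=O)N1` has not yet been measured. It differs from compound 1 in one place: pyridin-2-yl in place of 2-methylphenyl on a nitrogen on an aromatic ring. For the measured compounds named here, the only measured step, a number 10 percentage points higher from compound 2 to compound 3 (within the scatter), changes a group on an aromatic carbon of the ring attached to the nitrogen and stays within the scatter, so it says little about swapping the whole ring on a nitrogen on an aromatic ring. Going by the values given here, no measured pair here mirrors the change from compound 1 to compound 4. The step for compound 4 is therefore expected to be small, a number 5 percentage points higher from compound 1 to compound 4 (within the scatter), not beyond the scatter in either direction. Compound 4 is estimated at 7%, within a range from -5% to 22%.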

Compound 4, a percentage reported as inhibition, at one concentration (the size of the read-out at that concentration, not a potency): 9%
For compound 4 the middle estimate is 2 percentage points below the measured one; measured number inside the range.
By their numbers in this assay, from the lowest: compounds 1, 4, 2 and 3 (each within the scatter of the next, the first and the last beyond it).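

In this assay, the change on this nitrogen gives a number 7 percentage points higher from compound 1 to compound 4 (within the scatter), the first step shown at this place, since the earlier step only altered a group on an aromatic carbon of the attached ring. Replacing the whole 2-methylphenyl ring with pyridin-2-yl, which brings a ring nitrogen and a hydrogen-bond acceptor and loses one heavy atom, therefore does not move the read-out beyond the usual scatter at the one concentration tested. No supporting information is available to explain this small step.

The compounds shown leave open whether a saturated ring such as cyclohexyl, or an aromatic ring carrying a carboxylic acid, on this same nitrogen would shift the number beyond the scatter. They also leave open whether the same swap would give a similarly small step on the core of compound 2.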